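The compounds below may be only part of what the source reports. "The series", "measured", "known", "first", "only" and "open" are said of these compounds alone.

Of the compounds shown here, three sharing one core have been measured in a functional assay on the whole organism with Rattus norvegicus as the target, with a stated time of 4 h, at a dose of 40 mg/kg by the intraperitoneal route; on this read-out higher numbers stand for more inhibition at the one dose given (going by the name of the read-out) and lower numbers for less inhibition. Compound 1, `Cc1nc2c(OCc3ccccc3)cccn2c1C(N)=O`, gives 42% in this assay. Compound 2, `CC(=O)c1c(C)nc2c(OCc3ccccc3)cccn12`, gives 57%. Compound 3, `COCc1c(C)nc2c(OCc3ccccc3)cccn12`, gives 99%, the highest of the three; the step of a number 57 percentage points higher from compound 1 to compound 3 (beyond the scatter) and the step of a number 42 percentage points higher from compound 2 to compound 3 (beyond the scatter) are both large, while the step of a number 15 percentage points higher from compound 1 to compound 2 (beyond the scatter) is modest. Compound 4, `CCOCc1c(C)nc2c(OCc3ccccc3)cccn12`, is not yet measured. It differs from compound 3 by methyl in place of hydrogen on a saturated chain carbon bound to an oxygen on a saturated carbon. Among the compounds with values here, none of the measured steps touches this place: all three concern the group on the aromatic carbon, not the chain beyond the oxygen, so they do not bear on this change directly. With compound 3 already near the top of the scale, a step beyond the scatter can only run downward, and nothing in the data calls for one. Compound 4 is therefore expected to give about 92% in this assay, within 72% to 100%, a step of a number 7 percentage points lower from compound 3 to compound 4 (within the scatter) that is expected to stay within the scatter.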

Compound 4, a percentage reported as inhibition, in the whole organism at one dose (the size of the read-out at that dose, not a potency): 84%
The estimate for compound 4 lay 8 percentage points above the measured number, and the stated range covers the measured number.
By their numbers in this assay, from the lowest: compound 1; then compound 2; then compound 4; then compound 3.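

In this assay the chain beyond the oxygen turns out not to be neutral: going from methoxymethyl to ethoxymethyl, with methyl in place of hydrogen on the saturated chain carbon, gives a number 15 percentage points lower from compound 3 to compound 4 (beyond the scatter) and is the only step shown at this place. The ethoxymethyl group still keeps an advantage over the other two groups on the aromatic carbon, with a number 27 percentage points higher from compound 2 to compound 4 (beyond the scatter) and a number 42 percentage points higher from compound 1 to compound 4 (beyond the scatter) in the same assay, so the gain over acetyl and carbamoyl seen with methoxymethyl survives this change. The data shown offer no explanation for the drop from methoxymethyl to ethoxymethyl.

From the compounds shown here alone, a single step sets no trend, so it remains open whether a longer chain such as propoxymethyl would lower the number further. Going by these compounds, it is equally open how an amine or a carboxylic acid at the end of this chain would read.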